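Oligoether carbonate and ester series: working notes on solubility

The source may hold more compounds than are shown below. What is called first, only, known or untested is meant among the compounds shown, and "the series" means these compounds.

Measured so far:
compound 1 `COCCOCCOCCOCCOCCOCCOCCOC(=O)Oc1c(C(C)C)cccc1C(C)C`: 2730 ug/mL
compound 2 `COCCOCCOCCOCCOC(=O)Oc1c(C(C)C)cccc1C(C)C`: 380 ug/mL
compound 3 `COCCOCCOCCOCCOCCOCCOCCOCCOCCOCCOCC(=O)Oc1c(C(C)C)cccc1C(C)C`: > 371000 ug/mL

All three were run in a physicochemical assay for solubility, in phosphate buffer, at pH 7.4; on this read-out lower numbers stand for lower solubility and higher numbers for higher solubility. Compound 2 differs from compound 1 by hydrogen in place of (2-(2-methoxyethoxy)ethoxy)methyl on a saturated chain carbon bound to an oxygen on a saturated carbon; this gave a 7.2-fold lower number from compound 1 to compound 2 (0.86 log units; beyond the scatter). Compound 3 sits at the limit of > 371000 ug/mL in this assay, at which 1 of the 3 values shown sits, so its value is a limit of the assay and not a number. How the core of compound 3 differs from the core of compound 1 is not broken down here.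

Compound 4 `COCCOCCOCCOCCOCCOCCOCCOCC(=O)Oc1c(C(C)C)cccc1C(C)C` is not yet measured. Among the compounds with values here, it differs from compound 3 by hydrogen in place of (2-(2-methoxyethoxy)ethoxy)methyl on a saturated chain carbon bound to an oxygen on a saturated carbon, the same change as the one from compound 1 to compound 2, at the same place. Because compound 3 stands at the limit of > 371000 ug/mL in this assay, at which 1 of the 3 values shown sits, the starting point for this step is not a number, and a drop of the size seen from compound 1 to compound 2 would still leave a very high reading. Compound 4 is therefore expected at 150000 ug/mL, between 30000 ug/mL and 500000 ug/mL. That expectation means a step of an at least 2.4-fold lower number from compound 3 to compound 4 (0.39 log units; beyond the scatter).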

Compound 4, solubility: > 216000 ug/mL
Compound 4: no number, only a limit (the forecaster's own chance of this, stated with the estimate: 45%); middle value at least 1.4-fold (0.15 log units) from the limit.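

Compound 3 and compound 4 both read as limits in this assay, and the step between them cannot be read. The compounds shown leave open whether hydrogen in place of (2-(2-methoxyethoxy)ethoxy)methyl changes the reading in the ester series as it does in the carbonate series.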